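Solubility notes: cyano for tert-butoxycarbonyl on compound 2

This account rests on a few compounds, and the source may have more. Where it says the series, first, only, none or still open, it means among the compounds named here.

In a physicochemical assay for solubility (on this read-out lower numbers stand for lower solubility and higher numbers for higher solubility), compound 2 `COc1cc2cc(C(=O)CCC3CC[N+](C)(CC(=O)OC(C)(C)C)CC3)sc2cc1OC` stands at 1500 ug/mL, with compound 1 `COc1cc2cc(C(=O)CCC3CC[N+](C)(Cc4ccccc4)CC3)sc2cc1OC` at 2000 ug/mL within the scatter of it, so the two numbers cannot be told apart. Compound 3 `COc1cc2cc(C(=O)CCC3CC[N+](C)(CC#N)CC3)sc2cc1OC` differs from compound 2 by cyano in place of tert-butoxycarbonyl on a saturated chain carbon bound to an amine nitrogen in a ring. Within the data shown here, the only measured step at this place, a 1.3-fold lower number from compound 1 to compound 2 (0.12 log units; within the scatter), stayed within the scatter, and there is no other step on which to draw. On that basis no change beyond the scatter is expected, a 1.1-fold higher number from compound 2 to compound 3 (0.05 log units; within the scatter). Compound 3 is estimated at 1700 ug/mL, with a range from 850 ug/mL to 3400 ug/mL.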

Compound 3, solubility: 2000 ug/mL
Beside the measured number, compound 3's estimate is 1.2-fold (0.07 log units) below it; the range from low to high includes it.
By their numbers in this assay, from the lowest: compounds 2, 1 and 3 (each within the scatter of the next).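

In this assay cyano on a saturated chain carbon bound to an amine nitrogen in a ring gives a second and third step within the scatter (a 1.3-fold higher number from compound 2 to compound 3 (0.12 log units; within the scatter)) and (no change at the digits printed from compound 1 to compound 3 (within the scatter)). Phenyl, tert-butoxycarbonyl and cyano, three groups of quite different make-up, therefore cannot be told apart at this place on this read-out. Nothing on hand offers an explanation for this flat result.

Going by these compounds, whether a carboxylic acid or an amine at this place would move the number beyond the scatter remains open. So does the effect of a longer chain between the ring nitrogen and the terminal group.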